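Benzofuranyl in place of phenyl on compound 2

This account rests on a few compounds, and the source may have more. Where it says the series, first, only, none or still open, it means among the compounds named here.

In a functional assay on HCT-116 cells (Homo sapiens), read by MTT assay, with a stated time of 72 h (a lower number here means a stronger inhibitor, a higher number a weaker inhibitor), compound 1 `CSc1ncnc2c1c(-c1ccoc1)cn2[C@@H]1O[C@H](CO)[C@@H](O)[C@H]1O` gives 100 nM as a measured number. Compound 2 `O=c1[nH]cnc2c1c(-c1ccccc1)cn2[C@@H]1O[C@H](CO)[C@@H](O)[C@H]1O` gives only a limit of the assay, with > 20000 nM standing in place of a number. Within the data shown here, no measured step connects these two compounds.

Compound 3 `O=c1[nH]cnc2c1c(-c1cc3ccccc3o1)cn2[C@@H]1O[C@H](CO)[C@@H](O)[C@H]1O` departs from compound 2 by one change (1-benzofuran-2-yl in place of phenyl on an aromatic carbon): 1-benzofuran-2-yl in place of phenyl on an aromatic carbon of a five-membered aromatic ring with 1 nitrogen, part of a fused or bridged system of two rings. Since compound 2 reaches only a limit (> 20000 nM) compound 3 is expected to remain close to it, with no step beyond the scatter expected in this assay in either direction. The expected step of a number no higher from compound 2 to compound 3 (the limit leaves the size open) is only an estimate. For compound 3 the estimated value is 20000 nM (expected range 6000 nM to 40000 nM).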

Compound 3, half-maximal inhibitory concentration: > 20000 nM
Compound 3 ended at the assay's limit (the forecaster's own chance of this, stated with the estimate: 75%); the middle value lies on the limit itself.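

In this assay, among these compounds, compound 2 and compound 3 both stand at a limit of the assay and not at a number, so no step between them can be read: the limit of > 20000 nM in this assay, at which 2 of the 3 values shown sit.

The compounds shown leave open whether 1-benzofuran-2-yl in place of phenyl on this core changes the inhibition at all.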